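The source may hold more compounds than are shown below. What is called first, only, known or untested is meant among the compounds shown, and "the series" means these compounds.

For the measured compounds named here, compound 2 `CS(=O)(=O)Nc1ccc(CNC(=O)c2ccc(OC(F)(F)F)cc2)c(Cl)c1` gives the lower of the two numbers so far in an assay on HeLa cells for agonist activity at Bile acid receptor (Homo sapiens), read by a luciferase reporter, with a stated time of 24 h; a higher number here means that more compound is needed for the effect, a lower number that less compound is needed: compound 2 gives 1090 nM, and its nearest neighbour, compound 1 `CS(=O)(=O)Nc1ccc(CNC(=O)c2ccc(N3CCC3)cc2)c(Cl)c1`, gives 13000 nM in this assay. Going by the values given here, the one measured step, a 12-fold lower number from compound 1 to compound 2 (1.08 log units; beyond the scatter), is large and beyond the scatter. Compound 3 `CS(=O)(=O)Nc1ccc(CNC(=O)c2ccc(CC(F)(F)F)cc2)c(Cl)c1` differs from compound 2 in one place: 2,2,2-trifluoroethyl in place of trifluoromethoxy on an aromatic carbon. Among the compounds with values here, no measured step exchanges one of these two groups for the other, so the measured step bears on the new one only in showing that this position tolerates change of a large size. Within the data shown here, with one step and no direct precedent, the expectation for compound 3 is a number close to that of compound 2 in this assay, with no step beyond the scatter expected in either direction. Compound 3 is therefore estimated at 1500 nM in this assay, with a range from 400 nM to 6000 nM, which corresponds to an expected step of a 1.4-fold higher number from compound 2 to compound 3 (0.14 log units; within the scatter).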

Compound 3, half-maximal effective concentration: 4000 nM
Compound 3: the middle estimate sits 2.7-fold (0.43 log units) below what was measured; measured number inside the range.
By their numbers in this assay, from the lowest: compound 2; then compound 3; then compound 1.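

In this assay, the position para to a large group proves sensitive even to an exchange between two groups with the same count of heavy atoms: 2,2,2-trifluoroethyl in place of trifluoromethoxy gives a 3.7-fold higher number from compound 2 to compound 3 (0.56 log units; beyond the scatter). The same group still improves on azetidin-1-yl, with a 3.3-fold lower number from compound 1 to compound 3 (0.51 log units; beyond the scatter), so compound 3 falls between the other two compounds and all three groups are separated by steps beyond the scatter. Nothing available accounts for these differences, including whether the hydrogen-bond acceptor counted in trifluoromethoxy but not in 2,2,2-trifluoroethyl plays any part.

The compounds shown leave open whether another group at this position, such as a primary amine, a carboxylic acid or a longer fluorinated alkyl chain, would give a number lower than that of compound 2. They also leave open whether this order of groups would hold if the shared core were changed elsewhere.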